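Compound 3 to compound 4: methoxy for methyl

The source may hold more compounds than are shown below. What is called first, only, known or untested is meant among the compounds shown, and "the series" means these compounds.

In a functional assay on HeLa cells (Homo sapiens) for inhibition, read by MTT assay, with a stated time of 48 h (a higher number here means a weaker inhibitor, a lower number a stronger inhibitor), compound 1 `Cc1ccc(/C=C2\SC(=O)N(CCNC(=O)Nc3c(C)n(C)n(-c4ccccc4)c3=O)C2=O)cc1` gives 22400 nM and compound 2 `COc1cc(/C=C2\SC(=O)N(CCNC(=O)Nc3c(C)n(C)n(-c4ccccc4)c3=O)C2=O)cc(OC)c1OC` gives 15800 nM in the measured set. Compound 3 `Cc1ccc(/C=C2\SC(=O)N(CC(=O)Nc3c(C)n(C)n(-c4ccccc4)c3=O)C2=O)cc1` gives 53100 nM as the highest number of the three, with gaps to compound 1 and to compound 2 that both exceed the usual scatter.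

Compound 4 `COc1ccc(/C=C2\SC(=O)N(CC(=O)Nc3c(C)n(C)n(-c4ccccc4)c3=O)C2=O)cc1` is still unmeasured. It differs from compound 3 by methoxy in place of methyl on an aromatic carbon para to a large group, which reads as 4-methylphenyl to 4-methoxyphenyl.

Among the compounds with values here, only one measured step bears on this position. It replaces the 4-methylphenyl group with another aryl group and amounts to a 1.4-fold lower number from compound 1 to compound 2 (0.15 log units; within the scatter) in size. Within the data shown here, that step was taken on a different linker from the one in compound 3, so it is only indirect guidance, and no measured pair isolates methyl to methoxy. No change beyond the scatter is therefore expected in this assay, and neither direction is favoured. The estimated change is a 1.2-fold lower number from compound 3 to compound 4 (0.07 log units; within the scatter) and stays small. The expected value for compound 4 is 45000 nM with an estimated range of 22000 nM to 90000 nM for the measurement.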

Compound 4, half-maximal inhibitory concentration: 64800 nM
Compound 4: the middle estimate sits 1.4-fold (0.16 log units) below what was measured; measured number inside the range.
By their numbers in this assay, from the lowest: compounds 2 and 1 (each within the scatter of the next); then compounds 3 and 4 (each within the scatter of the next).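

In this assay the only pair shown that isolates this change gives a 1.2-fold higher number from compound 3 to compound 4 (0.09 log units; within the scatter) and so does not separate 4-methoxyphenyl from 4-methylphenyl at this position on the linker of compound 3. Methoxy adds one heavy atom and one hydrogen-bond acceptor relative to methyl, yet this exchange leaves the number within the scatter, a result that the earlier step to 3,4,5-trimethoxyphenyl, taken on the linker of compound 1, could suggest only indirectly. Nothing in the available data accounts for this flat result.

Still open, on these data alone, is whether methoxy for methyl also stays within the scatter on the linker of compound 1, which gives 22400 nM with the 4-methylphenyl group. Within the data shown here, also open is whether a group of another kind on this aromatic carbon, such as a hydroxyl, a fluorine, a dimethylamino group or a carboxylic acid, would move the number in this assay beyond the scatter, since methyl and methoxy are the only groups compared here on the linker of compound 3.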